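The source may report more compounds than this note shows. Statements on the series, on what has been measured and on what is new or still open speak of the compounds shown alone.

Compound 1 `COc1cccc(-c2nc3cc(F)ccc3[nH]2)c1Cl` gives 2620 nM in an assay for inhibition of Alpha amylase (Homo sapiens), with a stated time of 10 min; on this read-out higher numbers stand for weaker inhibition and lower numbers for stronger inhibition.
Compound 2 `COc1ccc(Br)c(-c2nc3cc(F)ccc3[nH]2)c1O` gives 2170 nM in this assay.
Compound 3 `COc1ccc(-c2nc3cc(Cl)ccc3[nH]2)c(Cl)c1OC` gives 1510 nM in this assay.

On these three numbers compound 2 stands second highest, but its gap to compound 1 and its gap to compound 3 both fall within the usual scatter of this kind of measurement, so the three compounds cannot be told apart on this evidence. None of them can be called stronger or weaker than another.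

Compound 4 `COc1ccc(Br)c(-c2nc3cc([N+](=O)[O-])ccc3[nH]2)c1O` has not yet been measured. It comes from compound 2 by a single change: nitro in place of fluoro on an aromatic carbon. Within the data shown here, no pair of measured compounds shows what this exchange does on its own, since each measured compound differs from the others in more than one place. With nothing to lean on beyond the three numbers and the change itself, the expectation is for a step from compound 2 to compound 4 that does not clearly rise above the scatter, in either direction.

Compound 4 is therefore expected to give about 1800 nM, with a range from 700 nM to 4500 nM. That estimate corresponds to an expected step of a 1.2-fold lower number from compound 2 to compound 4 (0.08 log units; within the scatter).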

Compound 4, half-maximal inhibitory concentration: 2290 nM
For compound 4 the middle estimate is 1.3-fold (0.10 log units) below the measured one, and the stated range covers the measured number.
By their numbers in this assay, from the lowest: compounds 3, 2, 4 and 1 (each within the scatter of the next).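

The exchange of fluoro for nitro on this aromatic carbon, which is meta to a fused ring and para to a fused ring, amounts to a 1.1-fold higher number from compound 2 to compound 4 (0.02 log units; within the scatter) in this assay, so the two compounds cannot be told apart in this measurement. Among these compounds, this is the first direct reading of a single change in the set, as the earlier compounds each differ in more than one place and so could not isolate any one group. Here, a fluoro of 1 heavy atom with 0 hydrogen-bond acceptors and a nitro of 3 heavy atoms with 2 hydrogen-bond acceptors occupy the same place with no difference that rises above the scatter, and no independent measurement is available to explain this result.

From the compounds shown here alone, whether the same holds for other groups at this carbon remains open, for example an amine, a carboxylic acid or a longer chain such as a butoxy group. Going by these compounds, it is also open whether the nitro-for-fluoro exchange would give a similar result on the core of compound 1, which carries different groups on its other ring.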